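Removing the para-methoxy group: an expected gain in potency

The source may hold more compounds than are shown below. What is called first, only, known or untested is meant among the compounds shown, and "the series" means these compounds.

Compound 1 `C[C@@H](Sc1nc2c(cnn2C)c(=O)n1-c1ccccc1)c1ccccc1`: 70 nM
Compound 2 `COc1ccc(C(C)Sc2nc3c(cnn3C)c(=O)n2-c2ccccc2)cc1`: 352 nM

Of the compounds shown here, two sharing one core have been measured in an assay on isolated protein for inhibition of aldehyde dehydrogenase 1A1 (Homo sapiens); a lower number here means a stronger inhibitor, a higher number a weaker inhibitor. Compound 1 gives 70 nM, while compound 2 gives 352 nM. Compound 2 thus stands at the higher of the two numbers, and its nearest neighbour, compound 1, lies below it by a gap that is beyond the usual scatter. Going by the values given here, no single-change step between the two measured compounds is recorded, so the pair only shows that compound 2 is the weaker inhibitor of the two.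

Compound 3 `CC(Sc1nc2c(cnn2C)c(=O)n1-c1ccccc1)c1ccccc1` has not yet been measured in this assay. It differs from compound 2 in one place: hydrogen in place of methoxy on an aromatic carbon. Among the compounds with values here, with only two measured compounds there is no recorded step of this kind, so the size of the effect is uncertain. The author nevertheless expects compound 3 to give a lower number than compound 2, because the number for compound 2 352 nM is the weakest seen so far, and estimates the step of a 3.2-fold lower number from compound 2 to compound 3 (0.51 log units; beyond the scatter) to lie beyond the scatter. For compound 3 the estimate is 110 nM, within a range from 40 nM to 300 nM.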

Compound 3, half-maximal inhibitory concentration: 130 nM
Estimate against measurement, compound 3: 1.2-fold (0.07 log units) below, within the range that was stated.
By their numbers in this assay, from the lowest: compounds 1 and 3 (each within the scatter of the next); then compound 2.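

In this assay, the change from 4-methoxyphenyl to phenyl now has a measured size in a single-change comparison: a 2.7-fold lower number from compound 2 to compound 3 (0.43 log units; beyond the scatter). Going by these compounds alone, the earlier pair could show only that compound 2 was the weaker inhibitor, whereas this step ties a difference beyond the scatter to this one place on the ring and shows that the methoxy group is not needed for inhibition at the level of compound 3. Within the data shown here, the second step, a 1.9-fold higher number from compound 1 to compound 3 (0.27 log units; within the scatter), lies within the scatter, so the two numbers cannot be told apart, and the only thing separating this pair is the following: the fact that one of compounds 1 and 3 is drawn with a defined configuration and the other without, at the place where they differ.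

The compounds shown leave open how a fluorine, a hydroxyl group or an amine at this same place on the ring would read in this assay, and so whether the step belongs to methoxy alone or to any group there. They also leave open what the opposite configuration at the stereocentre of the saturated chain carbon gives on its own.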